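The compounds below may be only part of what the source reports. "The series", "measured", "known", "first", "only" and "open" are said of these compounds alone.

Measured in an ADME assay on L6 cells (Rattus norvegicus) for cytotoxicity, read by resazurin assay, with a stated time of 72 h; on this read-out higher numbers stand for weaker inhibition and lower numbers for stronger inhibition:
- compound 1 `N=C(N)c1ccc(COc2ccc(Cl)cc2)cc1`: 20700000 nM
- compound 2 `CC(C)c1ccc(OCc2ccc(C(=N)N)cc2)cc1`: 5360000 nM
- compound 3 `COc1ccc(OCc2ccc(C(=N)N)cc2)cc1`: 143000000 nM

Among these three, compound 3 carries the highest number in this assay, at 143000000 nM, and its gaps to both of the others lie beyond the scatter. The next compound to be tested is compound 4 `N=C(N)c1ccc(COc2ccc(N)cc2)cc1`, which has amino in place of methoxy on an aromatic carbon.

For the measured compounds named here, no measured compound carries the amino group, so no step shows this change directly. The nearest evidence comes from the two steps that arrive at the methoxy group of compound 3. One is modest, a 6.9-fold higher number from compound 1 to compound 3 (0.84 log units; beyond the scatter), and the other is large, a 27-fold higher number from compound 2 to compound 3 (1.43 log units; beyond the scatter). A third step, a 3.9-fold lower number from compound 1 to compound 2 (0.59 log units; beyond the scatter), shows that the two other groups also differ from each other, so the size of a change at this carbon depends on the group involved. With compound 3 at the top of this small set, and both other groups giving lower numbers, a move down seems more likely than a move up, though only a modest one can be expected from so little evidence.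

The expected change is a 2.9-fold lower number from compound 3 to compound 4 (0.46 log units; beyond the scatter). For compound 4, the estimated value is 50000000 nM, with an expected range of 12000000 nM to 160000000 nM.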

Compound 4, half-maximal inhibitory concentration: > 271000000 nM
Compound 4: a limit, no number; the forecaster's own chance of this, stated with the estimate: 10%; at least 5.4-fold (0.73 log units) between middle value and limit.
By their numbers in this assay, from the lowest: compound 2; then compound 1; then compound 3. At a limit, above all of these: compound 4.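

In this assay, compound 4 gives no number but a limit: the limit of > 271000000 nM in this assay, at which 1 of the 4 values shown sits.

For the compounds shown here, with an at least 50-fold higher number from compound 2 to compound 4 (1.70 log units; beyond the scatter) and an at least 13-fold higher number from compound 1 to compound 4 (1.11 log units; beyond the scatter), both beyond the scatter, the amino group joins methoxy at the high end of this position, well apart from isopropyl and chloro, and the position now shows a wider spread than the earlier compounds could reveal. Against the methoxy group, however, the reading is much less firm: an at least 1.8-fold higher number from compound 3 to compound 4 (0.27 log units; that floor lies within the scatter) is a step whose floor lies within the scatter, so on its floor alone this change is not shown to separate the two groups. What the result adds is that a small change of group at this aromatic carbon, with methoxy leaving and amino entering, did not bring the number down, and the reading stayed at the top of the set.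

As far as these compounds go, how far the true value of compound 4 lies past its limit stays open, and with it the real size of the step from the methoxy group. Also open, from the compounds shown here alone, is whether a hydroxyl or a dimethylamino group on this carbon would sit with amino and methoxy or with isopropyl and chloro.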